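A few compounds are considered here, and "the series" means these few. Any claim that something is new, unique, unknown or untested is made for them only; others in the source may bear on it.

Measured so far in an ADME assay on isolated protein for inhibition of Amine oxidase [flavin-containing] B (Homo sapiens); a lower number here means a stronger inhibitor, a higher number a weaker inhibitor:

Compound 1, `C#CCNC1CCc2c(OCc3cccc(C(F)(F)F)c3)cccc21`: 5410 nM
Compound 2, `C#CCNC1CCc2c(SCCc3cccc(C)c3)cccc21`: 4960 nM
Compound 3, `C#CCNC1CCc2c(SCc3cccc(C)c3)cccc21`: > 100000 nM, which is a limit of the assay and not a number the limit of > 100000 nM in this assay, at which 1 of the 3 values shown sits.

Compound 2 holds the lowest of the two numbers in this assay, but the gap to compound 1 lies within the usual scatter, so the two cannot be told apart. Compound 3 stands apart in that it reaches only the limit.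

Compound 4, `C#CCNC1CCc2c(SCCc3cccc(Br)c3)cccc21`, has not yet been measured. It differs from compound 2 in one place: bromo in place of methyl on an aromatic carbon. Among the compounds with values here, no pair of measured compounds shows this same change, so the expectation rests on the value of compound 2 alone. The expected step, a 1.2-fold lower number from compound 2 to compound 4 (0.09 log units; within the scatter), is small, in no direction beyond the scatter. Compound 4 is therefore estimated at 4000 nM in this assay, with a likely range from 1500 nM to 12000 nM.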

Compound 4, half-maximal inhibitory concentration: 620 nM
Compound 4: the middle estimate sits 6.5-fold (0.81 log units) above what was measured; the measured number lies below the stated range.
By their numbers in this assay, from the lowest: compound 4; then compounds 2 and 1 (each within the scatter of the next). At a limit, above all of these: compound 3.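

In this assay, the exchange of 3-methylphenyl for 3-bromophenyl gives an 8.0-fold lower number from compound 2 to compound 4 (0.90 log units; beyond the scatter) and so lies beyond the scatter. This aromatic carbon, meta to a large group, therefore responds to what it carries, even though a single heavy atom is exchanged and no ring, hydrogen-bond donor, hydrogen-bond acceptor or net charge enters or leaves. Nothing measured here accounts for why bromo gives the lower number at this position.

As far as these compounds go, whether chloro, methoxy or a nitrile at this carbon would give a number like that of bromo remains open. From the compounds shown here alone, it is also open whether the same exchange of methyl for bromo would produce a step of similar size in the setting of compound 3, or whether bromo would do so in place of trifluoromethyl in compound 1.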